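Lengthening the Chain from Compound 3 to Compound 4

The compounds below may be only part of what the source reports. "The series", "measured", "known", "first", "only" and "open" are said of these compounds alone.

Of the compounds shown here, three have been measured so far in a functional assay on SH-SY5Y cells (Homo sapiens) for cytotoxicity, read by MTT assay, with a stated time of 72 h; on this read-out higher numbers stand for weaker inhibition and lower numbers for stronger inhibition. Compound 1 (`[O-][S+](CCCCN=C=S)c1ccccc1`) gives 8750 nM, compound 2 (`[O-][S+](CCCCN=C=S)Cc1ccccc1`) gives 5210 nM and compound 3 (`[O-][S+](CCCN=C=S)Cc1ccccc1`) gives 8890 nM. Compound 3 therefore lies within the usual scatter of both other compounds, and the three numbers cannot be ranked.

Compound 4 (`[O-][S+](CCCCCN=C=S)Cc1ccccc1`) has not yet been measured. Compared with compound 3, it carries this change: a group of 5 heavy atoms (3 carbon, 1 nitrogen, 1 sulfur; no ring) in place of a group of 3 heavy atoms (1 carbon, 1 nitrogen, 1 sulfur; no ring), on a saturated chain carbon, three bonds along the chain from a sulfur. The change sits on a saturated chain carbon, three bonds along the chain from a sulfur.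

For the measured compounds named here, only one measured step bears on it: a 1.7-fold higher number from compound 2 to compound 3 (0.23 log units; within the scatter). That step replaces a group with a smaller one, whereas compound 4 carries a larger one, so it points the opposite way. It is a single step within the scatter and offers only a weak hint. At most a small move towards lower numbers is therefore expected in this assay, with nothing beyond the scatter. The expected step is a 1.6-fold lower number from compound 3 to compound 4 (0.21 log units; within the scatter). For compound 4 the estimated value is 5500 nM, with an expected range from 2700 nM to 11000 nM.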

Compound 4, half-maximal inhibitory concentration: 7010 nM
Beside the measured number, compound 4's estimate is 1.3-fold (0.11 log units) below it; measured number inside the range.
By their numbers in this assay, from the lowest: compounds 2, 4, 1 and 3 (each within the scatter of the next).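

For the compounds shown here, compounds 2, 3 and 4 now allow this position to be read with three group sizes, where the earlier compounds gave only two. In this assay the larger group gives a 1.3-fold lower number from compound 3 to compound 4 (0.10 log units; within the scatter) and the group of 4 heavy atoms compared with the group of 3 gives a 1.3-fold higher number from compound 2 to compound 4 (0.13 log units; within the scatter) and so neither step separates the compounds. Within these three compounds, changing the chain at this place therefore shows no readable effect and no trend with group size, and nothing on hand offers an explanation for this result.

From the compounds shown here alone, whether a longer chain than the group of 5 heavy atoms would move the number beyond the scatter remains open. So does the effect of an amine or a carboxylic acid in place of these groups.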